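Urea series on a shared quinoline-type core: cytotoxicity notes

This account rests on a few compounds, and the source may have more. Where it says the series, first, only, none or still open, it means among the compounds named here.

Within the data shown here, compound 1 `Cc1cc(NC(=O)Nc2cccc(Cl)c2)c2ccccc2n1` is the one member with a number in an ADME assay on Raji cells (Homo sapiens) for cytotoxicity, with a stated time of 72 h; on this read-out lower numbers stand for an effect already at smaller amounts and higher numbers for an effect only at larger amounts of compound: compound 1 gives 18000 nM. Compound 2 `Cc1cc(NC(=O)Nc2ccc(F)cc2)c2ccccc2n1` reaches only the limit of the assay; in this assay compound 2 gives > 25000 nM. Compound 3 `Cc1cc(NC(=O)Nc2cccnc2)c2ccccc2n1` likewise sits at the limit; in this assay compound 3 gives > 25000 nM. Two of the three values therefore share the same floor (the limit of > 25000 nM in this assay, at which 2 of the 3 values shown sit), and the steps of an at least 1.3-fold higher number from compound 1 to compound 2 (0.14 log units; that floor lies within the scatter) and an at least 1.3-fold higher number from compound 1 to compound 3 (0.14 log units; that floor lies within the scatter) are floors that lie within the scatter, while a step that the two limits leave unreadable from compound 2 to compound 3 cannot be read.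

Compound 4 `Cc1cc(NC(=O)Nc2ccc(SC(F)(F)F)cc2)c2ccccc2n1` differs from compound 2 in one place: (trifluoromethyl)sulfanyl in place of fluoro on an aromatic carbon. Among the measured compounds shown here, none of the measured steps changes the group at this position of the ring, so no step bears directly on the change; the measured steps show only that two exchanges of the aryl group on the amide-type nitrogen left the read-out at or near the limit. The expected step of an at least 1.1-fold lower number from compound 2 to compound 4 (0.05 log units; that floor lies within the scatter) is accordingly none beyond the scatter. Compound 4 is therefore expected at about 22000 nM, within 7000 nM to 60000 nM, with a fair chance that only a limit is reported again.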

Compound 4, half-maximal effective concentration: 10000 nM
Estimate against measurement, compound 4: 2.2-fold (0.34 log units) above, within the range that was stated.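

Exchanging fluoro for (trifluoromethyl)sulfanyl on the aromatic carbon para to a large group gives an at least 2.5-fold lower number from compound 2 to compound 4 (0.39 log units; beyond the scatter) in this assay. Among these compounds, this is the first step printed as beyond the scatter, and it shows that the read-out can move with a change of the group on this ring, whereas the earlier exchanges of the whole aryl group gave only floors within the scatter or steps that cannot be read. The step remains a floor and not a full size because compound 2 sits at a limit: the limit of > 25000 nM in this assay, at which 2 of the 4 values shown sit.

Which part of the entering group goes with the step stays open; a methoxy group, an amine or a carboxylic acid at the same place would bear on that. Going by these compounds, whether the step carries over to other aryl groups on the amide-type nitrogen also stays open.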